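This account rests on a few compounds, and the source may have more. Where it says the series, first, only, none or still open, it means among the compounds named here.

Measured so far:
compound 1, `O=C1NC(=O)/C(=C\c2ccc(OCC(=O)N3N=C(c4ccccc4)CC3c3ccc(Br)cc3)cc2)S1`, 1200 nM
compound 2, `O=C1NC(=O)/C(=C\c2ccc(OCC(=O)N3N=C(c4ccc(F)cc4)CC3c3ccco3)cc2)S1`, 880 nM

In an assay on cells for inhibition of histone deacetylase 4 (Homo sapiens), read by fluorescence, with a stated time of 30 min (a lower number here means a stronger inhibitor, a higher number a weaker inhibitor), compound 2 gives 880 nM. Compound 1 gives 1200 nM in this assay. For the measured compounds named here, of the two numbers the one for compound 2 sits at the bottom, yet the gap to compound 1 lies within the usual scatter, so the two compounds count as indistinguishable on the data so far. Going by the values given here, no pair of measured compounds differs in a single place, so no measured step is available to calibrate the next change.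

Compound 3, `Cc1ccc(C2CC(c3ccc(F)cc3)=NN2C(=O)COc2ccc(/C=C3/SC(=O)NC3=O)cc2)cc1`, differs from compound 2 in one place: 4-methylphenyl in place of furan-2-yl on a saturated ring carbon. Compound 1 carries a six-membered aromatic ring of carbon only at the same place, and its number in this assay is within the scatter of that of compound 2, so an exchange of this kind is expected to move the number little.

Compound 3 is expected to land near compound 2, with the step of a 1.1-fold higher number from compound 2 to compound 3 (0.06 log units; within the scatter) expected to stay within the scatter. The estimate for compound 3 in this assay is 1000 nM, with a range from 400 nM to 2500 nM.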

Compound 3, half-maximal inhibitory concentration: 1800 nM
Compound 3: the middle estimate sits 1.8-fold (0.26 log units) below what was measured; the measured number falls inside the stated range.
By their numbers in this assay, from the lowest: compounds 2, 1 and 3 (each within the scatter of the next, the first and the last beyond it).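

Notes on the saturated ring carbon: in this assay, 4-methylphenyl in place of furan-2-yl gives a 2.0-fold higher number from compound 2 to compound 3 (0.31 log units; beyond the scatter), the first exchange in the series that can be read at a single place. The step is modest but lies beyond the scatter, so this position is not silent to the group it carries, and compound 3, at 1800 nM, still remains measurable with the larger group in place. Nothing on hand bears on what lies behind the step.

The exchange alters several things at once: the entering group has a six-membered aromatic ring of carbon only and a methyl group, whereas the leaving group has a five-membered aromatic ring with one oxygen, so these compounds cannot assign the step to any one of those features. Open as well is how this position would respond to thiophen-2-yl, which would keep the five-membered aromatic ring with sulfur in place of oxygen, to 4-methoxyphenyl, or to a group such as a carboxylic acid or an amine on the ring.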